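The source may hold more compounds than are shown below. What is called first, only, known or untested is meant among the compounds shown, and "the series" means these compounds.

Compound 2 `O=C1Nc2ccccc2/C1=C\c1c(Cl)n(CCCc2ccccc2)c2ccccc12` is the starting point here. In a functional assay on cells (Cancer cell lines, Homo sapiens) for cytotoxicity, with a stated time of 48 h (a lower number here means a stronger inhibitor of growth, a higher number a weaker inhibitor of growth), compound 2 gives 10000 nM. Compound 3 `COc1cc2c(cc1C)NC(=O)/C2=C/c1c(Cl)n(Cc2cc(OC)c(OC)c(OC)c2)c2cc(C)c(OC)cc12` gives 10000 nM in this assay, level with compound 2 at the digits recorded. Compound 1 `O=C1Nc2ccccc2/C1=C\c1c(Cl)n(Cc2ccccc2)c2ccccc12` gives 12900 nM in this assay, and the step of a 1.3-fold lower number from compound 1 to compound 2 (0.11 log units; within the scatter) lies within the scatter, so all three measured numbers sit within the scatter of one another and none can be ranked against the others.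

Compound 4 `O=C1Nc2ccc(Cl)cc2/C1=C\c1c(Cl)n(CCCc2ccccc2)c2ccccc12` arises from compound 2 by one change: chloro in place of hydrogen on an aromatic carbon. The only measured step among these compounds, from compound 1 to compound 2, concerns the chain bound to the aromatic nitrogen and not the ring where this chloro enters, and it was within the scatter. Within the data shown here, no measured step therefore bears directly on the change, and nothing in the data points to a shift beyond the scatter in either direction. Compound 4 is expected to give about 9000 nM in this assay, within a range of 3000 nM to 27000 nM, an estimated step of a 1.1-fold lower number from compound 2 to compound 4 (0.05 log units; within the scatter).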

Compound 4, concentration for 50% growth inhibition: 2190 nM
The estimate for compound 4 lay 4.1-fold (0.61 log units) above the measured number; the measured number lies below the stated range.
By their numbers in this assay, from the lowest: compound 4; then compounds 2, 3 and 1 (each within the scatter of the next).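

In this assay the chloro in place of hydrogen brings a 4.6-fold lower number from compound 2 to compound 4 (0.66 log units; beyond the scatter) and is the only step among these compounds that lies beyond the scatter. It shows that this aromatic carbon, on a six-membered aromatic ring of carbon only within a fused system of two rings, is a place where a single added heavy atom moves the number, which the change on the chain bound to the aromatic nitrogen between compound 1 and compound 2 did not do. Nothing measured here accounts for this step.

As far as these compounds go, it remains open whether a fluoro, a methoxy or a nitrile on this same carbon would move the number as chloro does, or whether chloro on another carbon of this ring would do the same. Also open, from the compounds shown here alone, is whether the chloro brings a similar step on the chain of compound 1.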